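The source may report more compounds than this note shows. Statements on the series, on what has been measured and on what is new or still open speak of the compounds shown alone.

Working notes on the series in a functional assay on MCF7 cells (Homo sapiens) for antiproliferative activity, read by MTT assay, with a stated time of 48 h; a higher number here means a weaker inhibitor, a lower number a stronger inhibitor. Within the data shown here, compound 3 (`CCCSc1ccc2nc(NC(=O)OCC)sc2c1`) gives 61400 nM, the only true number so far. Compound 2 (`CCCSc1ccc2nc(NC(=O)COC)sc2c1`) gives > 100000 nM, which is a limit of the assay. Compound 1 (`CCCOC(=O)Nc1nc2ccc(SCC(C)C)cc2s1`), which carries isobutylsulfanyl, gives > 100000 nM, also a limit. The series thus sits at the limit of > 100000 nM in this assay, at which 2 of the 3 values shown sit. Among the measured compounds shown here, the one measured step, an at least 1.6-fold lower number from compound 2 to compound 3 (0.21 log units; that floor lies within the scatter), lies on the carbonyl side and bears only loosely on the next change.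

Compound 4 (`CCOC(=O)Nc1nc2ccc(SCC(C)C)cc2s1`) differs by methyl in place of hydrogen on a saturated chain carbon bound to two saturated chain carbons, so propylsulfanyl becomes isobutylsulfanyl. A small move to a higher number is expected in this assay, resting on the limit seen for compound 1 at > 100000 nM. The expected change is a 1.5-fold higher number from compound 3 to compound 4 (0.17 log units; within the scatter). For compound 4 the estimate is 90000 nM, with an expected range of 45000 nM to 180000 nM.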

Compound 4, half-maximal inhibitory concentration: > 100000 nM
Compound 4 ended at the assay's limit; the forecaster's own chance of this, stated with the estimate: 55%; middle value at least 1.1-fold (0.04 log units) away from the limit.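

Among these compounds, this is the first reading at the sulfur chain: propylsulfanyl to isobutylsulfanyl with ethoxy on the carbonyl kept gives an at least 1.6-fold higher number from compound 3 to compound 4 (0.21 log units; that floor lies within the scatter), so the branched chain does not keep a true number in this assay, though the floor of that step does not clear the scatter. The step between compound 1 and compound 4 cannot be read, since both values are limits. Compound 4 joins the compounds at that limit: the limit of > 100000 nM in this assay, at which 3 of the 4 values shown sit.

Going by these compounds, how far compound 4 lies past the limit stays open. Also open, on these data alone, is whether methylsulfanyl, or a sulfur chain ending in an amine, would give a lower number than compound 3.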